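The source may hold more compounds than are shown below. What is called first, only, known or untested is meant among the compounds shown, and "the series" means these compounds.

In a functional assay on KB cells (Homo sapiens) for cytotoxicity, read by MTT assay, with a stated time of 3 days (on this read-out higher numbers stand for weaker inhibition and lower numbers for stronger inhibition), three compounds sharing one core have been measured. Compound 1 (`N#Cc1c(O)nc(SCc2nc3ccccc3[nH]2)nc1-c1ccccc1`) gives 6.2 nM, compound 2 (`N#Cc1c(Cl)nc(SCc2nc3ccccc3[nH]2)nc1-c1ccccc1`) gives 3.7 nM and compound 3 (`N#Cc1c(NNC(N)=S)nc(SCc2nc3ccccc3[nH]2)nc1-c1ccccc1`) gives 3 nM. The third value stands level with the second, a 1.2-fold lower number from compound 2 to compound 3 (0.09 log units; within the scatter), and apart from the first, a 2.1-fold lower number from compound 1 to compound 3 (0.32 log units; beyond the scatter).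

Compound 4 (`N#Cc1c(NC(N)=S)nc(SCc2nc3ccccc3[nH]2)nc1-c1ccccc1`) differs from compound 3 in one place: a group of 3 heavy atoms (1 carbon, 1 nitrogen, 1 sulfur; no ring) in place of a group of 4 heavy atoms (1 carbon, 2 nitrogen, 1 sulfur; no ring), on a nitrogen on an aromatic ring. Among the compounds with values here, no measured step makes this exact change. The closest evidence is the exchange of groups on an aromatic carbon, which gave a 1.7-fold lower number from compound 1 to compound 2 (0.22 log units; within the scatter) and also a 1.2-fold lower number from compound 2 to compound 3 (0.09 log units; within the scatter). From the compounds shown here alone, the largest of these exchanges was only modest, so no step beyond the scatter is expected in this assay, though the evidence is indirect and the direction remains open. The estimated 1.2-fold higher number from compound 3 to compound 4 (0.07 log units; within the scatter) is expected to be small. Compound 4 is expected at an estimated 3.5 nM, with a range from 1.5 nM to 8 nM.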

Compound 4, half-maximal inhibitory concentration: 3.2 nM
Beside the measured number, compound 4's estimate is 1.1-fold (0.04 log units) above it; the measured number falls inside the stated range.
By their numbers in this assay, from the lowest: compounds 3, 4, 2 and 1 (each within the scatter of the next, the first and the last beyond it).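

In this assay, exchanging the group of 4 heavy atoms for the group of 3 heavy atoms on a nitrogen on an aromatic ring gives a 1.1-fold higher number from compound 3 to compound 4 (0.03 log units; within the scatter), so the shorter group cannot be told apart from the longer one on this read-out. The other two comparisons give a 1.2-fold lower number from compound 2 to compound 4 (0.06 log units; within the scatter) and a 1.9-fold lower number from compound 1 to compound 4 (0.29 log units; within the scatter), which places compound 4 within the scatter of all three earlier compounds, whereas the step from compound 1 to compound 3 lay just beyond it. The data shown offer no measurement that could explain these numbers.

The compounds shown leave open whether a longer chain on that nitrogen would also stay level with compound 3. They also leave open how a plain amine or a methoxy group on the aromatic carbon would compare.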